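The source may report more compounds than this note shows. Statements on the series, on what has been measured and on what is new or still open speak of the compounds shown alone.

In an ADME assay on MT4 cells (Homo sapiens) for activation, read by MTT assay (on this read-out higher numbers stand for lower toxicity in this test and lower numbers for higher toxicity in this test), compound 1 (`CCCSc1nc(Cc2c(F)cccc2Cl)cc(=O)[nH]1`) gives > 80000 nM as a limit of the assay. Among the compounds with values here, compound 2 (`CCCCSc1nc(Cc2c(F)cccc2Cl)cc(=O)[nH]1`) stands at > 76000 nM as a limit too, so its place is known only as a limit, and the one other value shown is also a limit. The next change is cyclopentyl in place of butyl on a sulfur and reads, in words, cyclopentyl in place of butyl on a sulfur, which leads to compound 3 (`O=c1cc(Cc2c(F)cccc2Cl)nc(SC2CCCC2)[nH]1`). Within the data shown here, only one measured step bears on it. That is a step that the two limits leave unreadable from compound 1 to compound 2 and it concerns methyl in place of hydrogen on a saturated chain carbon, three bonds along the chain from a sulfur. Among the measured compounds shown here, it offers no size to carry over, and no measured step involves a ring on the sulfur. No step beyond the usual scatter is therefore expected in this assay and no direction is assigned, and a further limit is the likely report. The estimated outcome is an at least 1.0-fold lower number from compound 2 to compound 3 (0.01 log units; that floor lies within the scatter) as the expected step. For compound 3 the estimate is 74000 nM with an expected range of 30000 nM to 110000 nM on this read-out.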

Compound 3, half-maximal cytotoxic concentration: > 74000 nM
Compound 3: only a limit was reported (the forecaster's own chance of this, stated with the estimate: 80%); the middle value sits exactly at the limit.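

In this assay compound 3 gives > 74000 nM, a limit of the assay. Within the data shown here, compound 1 and compound 2 also stand only as limits, so no step among compound 1, compound 2 and compound 3 can be read. The compounds shown leave open whether exchanging propyl, butyl or cyclopentyl on the sulfur changes this read-out at all.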